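The source may hold more compounds than are shown below. What is called first, only, known or untested is meant among the compounds shown, and "the series" means these compounds.

Compound 2 `CCN(CC)Cc1cccc(Nc2nc3ccccc3[nH]2)c1O` carries a shared core with an unsubstituted aromatic nitrogen. In an ADME assay on CHO cells (Cricetulus griseus) for inhibition, read by MTT assay (a higher number here means a weaker inhibitor, a lower number a stronger inhibitor), compound 2 gives > 50000 nM, which is a limit of the assay and not a number. Compound 1 `CCN(CC)Cc1cccc(Nc2nc3ccccc3n2Cc2ccc(F)cc2)c1O` differs from it by 4-fluorobenzyl in place of hydrogen on an aromatic nitrogen. In this assay compound 1 gives > 50000 nM, again a limit of the assay. The step that the two limits leave unreadable from compound 2 to compound 1 is therefore not readable in size. Compound 3 `CCN(CC)Cc1cc(Nc2nc3ccccc3[nH]2)ccc1O` has the same atoms as compound 2 joined differently; the difference between the two cores is not broken down here. In this assay compound 3 gives > 50000 nM, a limit of the assay. Compound 4 `CCN(CC)Cc1cc(Nc2nc3ccccc3n2Cc2ccc(F)cc2)ccc1O` is unmeasured and differs from compound 3 by 4-fluorobenzyl in place of hydrogen on an aromatic nitrogen, the same change. Since every value shown sits at the limit of > 50000 nM in this assay, at which 3 of the 3 values shown sit, the step that the limit leaves unreadable from compound 3 to compound 4 is expected to stay unreadable. Compound 4 is estimated at 80000 nM, between 30000 nM and 300000 nM, most likely reported as a limit.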

Compound 4, half-maximal inhibitory concentration: 12000 nM
Compound 4: middle estimate off by 6.7-fold (0.82 log units), on the high side; the measured number lies below the stated range.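

On the core of compound 3, 4-fluorobenzyl in place of hydrogen on an aromatic nitrogen gives an at least 4.1-fold lower number from compound 3 to compound 4 (0.61 log units; beyond the scatter) in this assay, so compound 4 is a stronger inhibitor than compound 3, by an amount that may be larger still since the value of compound 3 is only a limit of the assay. The same change on the core of compound 2 cannot be read, because compound 2 and compound 1 both stand at a limit: the limit of > 50000 nM in this assay, at which 3 of the 4 values shown sit. The change is therefore shown to lower the number on one core only, and nothing shows whether it does so on the other.

From the compounds shown here alone, whether a plain benzyl or a chain ending in an amine on that aromatic nitrogen would also lower the number remains open. Going by these compounds, it is equally open whether the fluorine of the 4-fluorobenzyl group plays any part in the step.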